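Compound 3 against a cytotoxicity limit

The compounds below may be only part of what the source reports. "The series", "measured", "known", "first", "only" and "open" are said of these compounds alone.

Measured so far:
- compound 1 `COc1ccc(-c2[nH]c3cc(F)ccc3c2Cn2ccnc2)cc1`: > 1000000 nM
- compound 2 `Fc1ccc2c(Cn3cncn3)c(-c3ccc(Cl)cc3)[nH]c2c1`: > 1000000 nM

In an ADME assay on MCF7 cells (Homo sapiens) for cytotoxicity, read by MTT assay, with a stated time of 48 h (a higher number here means a weaker inhibitor, a lower number a stronger inhibitor), compound 2 gives > 1000000 nM, which is a limit of the assay and not a number. Compound 1 gives > 1000000 nM, likewise a limit. Going by the values given here, the data therefore hold the limit of > 1000000 nM in this assay, at which 2 of the 2 values shown sit, and no measured step.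

Compound 3 `COc1ccc(-c2[nH]c3cc(F)ccc3c2Cn2cncn2)cc1` differs from compound 2 by methoxy in place of chloro on an aromatic carbon, para to a large group, so 4-chlorophenyl becomes 4-methoxyphenyl.

No change beyond the scatter is expected in this assay, an expectation that rests on compound 2 with > 1000000 nM, itself a limit. The expected size of the change is a number no higher from compound 2 to compound 3 (the limit leaves the size open). A report as a limit is the likely outcome. For compound 3 the estimated value is 1000000 nM, with an expected range of 400000 nM to 3000000 nM.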

Compound 3, half-maximal inhibitory concentration: 325000 nM
Estimate against measurement, compound 3: 3.1-fold (0.49 log units) above; measured number below the stated range.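

In this assay, methoxy in place of chloro on an aromatic carbon, para to a large group, gives an at least 3.0-fold lower number from compound 2 to compound 3 (0.48 log units; beyond the scatter), so this position can move the read-out when the 1H-1,2,4-triazol-1-yl group is present. The change at the other place, 1H-1,2,4-triazol-1-yl in place of 1H-imidazol-1-yl, gives an at least 3.0-fold lower number from compound 1 to compound 3 (0.48 log units; beyond the scatter), so in the presence of the 4-methoxyphenyl group the azole matters as well. Of the three compounds, only compound 3 carries a number and not a limit: the limit of > 1000000 nM in this assay, at which 2 of the 3 values shown sit.

From the compounds shown here alone, both steps are bounded on one side only, so their full size stays open. Also open, going by these compounds, is whether ethoxy or an amine in place of methoxy would keep, lower or lose the number seen for compound 3.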